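The compounds below may be only part of what the source reports. "The series", "measured", "known", "first", "only" and "open" are said of these compounds alone.

Three compounds of the series carry a measured result in an ADME assay on L6 cells (Rattus norvegicus) for cytotoxicity, read by resazurin assay, with a stated time of 70 h; on this read-out higher numbers stand for an effect only at larger amounts of compound and lower numbers for an effect already at smaller amounts. Compound 1 `CC(=O)Nc1cnc2[nH]c(=O)n([C@H]3CC[C@@H](C(C)(C)C)CC3)c(=O)c2c1` gives 15000 nM. Compound 2 `CC(=O)Nc1cnc2[nH]c(=O)n([C@H]3CC[C@H](C(C)C)CC3)c(=O)c2c1` gives 32000 nM, the highest of the three. Compound 3 `CC(=O)Nc1cnc2[nH]c(=O)n([C@H]3CC[C@@H](C(C)C)CC3)c(=O)c2c1` gives 16000 nM.

Compound 3 arises from compound 1 by the change (hydrogen in place of methyl on a saturated chain carbon bound to two saturated chain carbons and a saturated ring carbon); the step is a 1.1-fold higher number from compound 1 to compound 3 (0.03 log units; within the scatter). Compound 3 also relates to compound 2: the step of a 2.0-fold lower number from compound 2 to compound 3 (0.30 log units; within the scatter) is set against (the fact that compounds 2 and 3 differ only in the configuration as drawn). The difference between the core of compound 1 and the core of compound 2 is not broken down here.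

Compound 4 `CC[C@H]1CC[C@H](n2c(=O)[nH]c3ncc(NC(C)=O)cc3c2=O)CC1` has not been measured. Relative to compound 2 it carries hydrogen in place of methyl on a saturated chain carbon bound to a saturated chain carbon and a saturated ring carbon. Going by the values given here, this is the same kind of change as the one from compound 1 to compound 3, but the place differs: there the carbon was bound to two saturated chain carbons and a saturated ring carbon, here to a saturated chain carbon and a saturated ring carbon. Since the earlier step of a 1.1-fold higher number from compound 1 to compound 3 (0.03 log units; within the scatter) stayed within the scatter, the expected step is a 1.0-fold higher number from compound 2 to compound 4 (0.01 log units; within the scatter), resting on compound 2 at 32000 nM. The estimate for compound 4 in this assay is 33000 nM, with a range from 16000 nM to 70000 nM.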

Compound 4, half-maximal effective concentration: 215000 nM
Compound 4: the middle estimate sits 6.5-fold (0.81 log units) below what was measured; measured number outside the range, above it.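

In this assay, the replacement of methyl by hydrogen, here isopropyl to ethyl, gives a 6.7-fold higher number from compound 2 to compound 4 (0.83 log units; beyond the scatter), so the number moves on this core while no such move appears on the core of compound 1. The replacement therefore does not carry over unchanged between these two cores: the same change on two cores in this assay, a 1.1-fold higher number (0.03 log units; within the scatter) from compound 1 to compound 3 and a 6.7-fold higher number (0.83 log units; beyond the scatter) from compound 2 to compound 4, 6.3-fold (0.80 log units) apart, beyond the scatter of two such steps. This is one pair of steps, which shows that the outcome of this replacement can depend on its setting but gives no general rule, and it cannot separate the drawn configuration from the place of the change, where the carbon bears different neighbours in the two steps.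

Open, on these data alone, is the ethyl chain on the drawn configuration of compound 3, which would give the replacement a third setting and show whether the high number of compound 4 follows the configuration. Also open, as far as these compounds go, is how a methyl group, a longer chain such as n-butyl, or an amine at this place would read on either core.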